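The compounds below may be only part of what the source reports. "The series", "measured", "known", "first", "only" and "open" are said of these compounds alone.

Of the compounds shown here, three have been read so far in an ADME assay on CHO cells (Cricetulus griseus) for inhibition, read by MTT assay; a lower number here means a stronger inhibitor, a higher number a weaker inhibitor. Compound 1 `Cc1cc(CNC(C)(C)C)c(O)c(Nc2nc3c(Cl)cc(Cl)cc3[nH]2)c1` gives 25800 nM in this read-out, and compound 3 `CC(C)(C)NCc1cc(C(C)(C)C)cc(Nc2nc3cc(F)c(F)cc3[nH]2)c1O` gives 34200 nM in the same read-out, so these two numbers lie within the scatter of each other. Compound 2 `CCN(CC)Cc1ccc(Nc2nc3ccccc3[nH]2)cc1O` has only a limit of > 50000 nM as its result and no number. Compound 3 therefore holds no separate place from compound 1 on the numbers available.

The step under consideration leads from compound 3 to compound 4 `Cc1cc(CNC(C)(C)C)c(O)c(Nc2nc3cc(F)c(F)cc3[nH]2)c1` which has not yet been measured. The change is methyl in place of tert-butyl on an aromatic carbon, para to a hydroxy group (methyl in place of tert-butyl on an aromatic carbon). Among the measured compounds shown here, no measured pair isolates this change. For the measured compounds named here, the expectation rests on compound 3 at 34200 nM as the starting point and on compound 1 at 25800 nM as the only other number, and on that basis no shift beyond the scatter is expected in this assay for this change. The estimated move a 1.1-fold lower number from compound 3 to compound 4 (0.03 log units; within the scatter) is expected to stay within the scatter. For compound 4 the expected value is 32000 nM with an estimated range from 16000 nM to 50000 nM in this assay. A result that is only a limit remains possible.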

Compound 4, half-maximal inhibitory concentration: 16700 nM
Compound 4: the middle estimate sits 1.9-fold (0.28 log units) above what was measured, and the stated range covers the measured number.
By their numbers in this assay, from the lowest: compounds 4, 1 and 3 (each within the scatter of the next, the first and the last beyond it). At a limit, above all of these: compound 2.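

Among the compounds shown here, this position, on an aromatic carbon para to a hydroxy group, is the first place where a single change can be read in this assay: methyl in place of tert-butyl gives a 2.0-fold lower number from compound 3 to compound 4 (0.31 log units; beyond the scatter), so the position is not silent in this read-out. For the compounds shown here, the loss of the larger group is tolerated here, and the number moves towards stronger inhibition, though only this one pair on the shared core supports that direction, and no trend across alkyl groups can be drawn from it. Nothing given here bears on why the number moves with this change.

Open, on these data alone, is how other groups at this position would read, whether ethyl or isopropyl, which would fill in the range from methyl to tert-butyl, or groups of another kind, such as a methoxy group, an amine or a carboxylic acid. Going by these compounds alone, also open is whether the same step would hold with other substituents elsewhere on the shared core, since no second pair isolates this change.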